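Trimming the Benzylamine of Compound 1 to Methylamine

The compounds below may be only part of what the source reports. "The series", "measured", "known", "first", "only" and "open" are said of these compounds alone.

Compound 1 `O=C(NCc1ccc(F)cc1)c1nc(Br)c2cccnc2c1NCc1ccccc1` was examined in a functional assay on HCT-116 cells (Homo sapiens) for cytotoxicity, read by MTT assay, with a stated time of 72 h; on this read-out lower numbers stand for stronger inhibition and higher numbers for weaker inhibition. In this assay compound 1 gives > 20000 nM, which is a limit of the assay rather than a number, standing at the limit of > 20000 nM in this assay, at which 1 of the 3 values shown sits. Compound 2 `O=CNCCCCCCNc1nc(C(=O)NCc2ccc(F)cc2)c(O)c2ncccc12` gives 4000 nM in this assay. Compound 3 `N[C@H]1CC[C@H](Nc2c(C(=O)NCc3ccc(F)cc3)nc(N3CCCCS3(=O)=O)c3cccnc23)CC1` gives > 10000 nM in this assay, again a limit, at the limit of > 10000 nM in this assay, at which 1 of the 3 values shown sits. For the measured compounds named here, no step between measured compounds that differ in one place is available, so compound 1 stands only as one of two limits beside a single numbered value. Compound 4 `CNc1c(C(=O)NCc2ccc(F)cc2)nc(Br)c2cccnc12` differs from compound 1 in one place: hydrogen in place of phenyl on a saturated chain carbon bound to a nitrogen on an aromatic ring. The expected step of a number no higher from compound 1 to compound 4 (the limit leaves the size open) is small, within the usual scatter. Compound 4 is therefore estimated at 20000 nM, between 6000 nM and 60000 nM, most likely reported again as a limit.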

Compound 4, half-maximal inhibitory concentration: > 20000 nM
Compound 4: no number, only a limit (the forecaster's own chance of this, stated with the estimate: 70%); the middle value lies on the limit itself.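

Compound 1 and compound 4 both stand at a limit of this assay rather than at a number, so the step between them cannot be read. The compounds shown leave open whether replacing benzylamino with methylamino shifts cytotoxicity at all.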